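Methylating the sulfanyl group of a quinazoline growth inhibitor

The compounds below may be only part of what the source reports. "The series", "measured", "known", "first", "only" and "open" are said of these compounds alone.

Measured compounds:
- compound 1 `COc1ccc(CNc2nc([Se]C)nc3ccccc23)cc1`: > 100000 nM
- compound 2 `[SeH]c1nc(NCc2ccccc2)c2cccnc2n1`: 30500 nM
- compound 3 `Sc1nc(NCc2ccccc2)c2ccccc2n1`: 82400 nM

In a functional assay on CCRF-CEM cells (Homo sapiens) for cytotoxicity, read by MTT assay, with a stated time of 72 h (on this read-out lower numbers stand for stronger inhibition of growth and higher numbers for weaker inhibition of growth), compound 1 `COc1ccc(CNc2nc([Se]C)nc3ccccc23)cc1` reaches only a limit, > 100000 nM, not a number. Compound 2 `[SeH]c1nc(NCc2ccccc2)c2cccnc2n1` gives 30500 nM in this assay. Compound 3 `Sc1nc(NCc2ccccc2)c2ccccc2n1` gives 82400 nM in this assay, the higher of the two numbers; the gap between compound 2 and compound 3 lies beyond the usual scatter, so compound 3 is the weaker of these two.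

Compound 4 `CSc1nc(NCc2ccccc2)c2ccccc2n1` has not yet been measured. It differs from compound 3 by methyl in place of hydrogen on a sulfur. Going by the values given here, with no measured step of this kind among the compounds here, and with compound 1, which also carries a methyl on its chalcogen, sitting at the limit (the limit of > 100000 nM in this assay, at which 1 of the 3 values shown sits), the expected step of a 1.3-fold higher number from compound 3 to compound 4 (0.13 log units; within the scatter) in this assay is towards a higher number, though a step within the scatter cannot be ruled out. Compound 4 is therefore estimated at 110000 nM in this assay, within a range of 35000 nM to 350000 nM.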

Compound 4, concentration for 50% growth inhibition: 87900 nM
Compound 4: the middle estimate sits 1.3-fold (0.10 log units) above what was measured, and the stated range covers the measured number.
By their numbers in this assay, from the lowest: compound 2; then compounds 3 and 4 (each within the scatter of the next). At a limit, above all of these: compound 1.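

In this assay, going by these compounds alone, there is a 1.1-fold higher number from compound 3 to compound 4 (0.03 log units; within the scatter) when methyl takes the place of hydrogen on this sulfur, the first step that can be read at this position. The hydrogen on the sulfur can thus give way to methyl with no change beyond the scatter, and growth inhibition stays weak on both sides of the step. Compound 1 carries a methyl on its selenium but remains a limit and not a number, and it offers no step to set beside this one: the limit of > 100000 nM in this assay, at which 1 of the 4 values shown sits.

Methyl is the only group on this sulfur among the compounds shown, so the effect of a longer chain such as butyl, or of a chain ending in an amine or a carboxylic acid, remains open. Also open, from the compounds shown here alone, is whether the same change on selenium would give a similarly small step.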